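A few compounds are considered here, and "the series" means these few. Any claim that something is new, unique, unknown or untested is made for them only; others in the source may bear on it.

Measured compounds:
- Compound 1, `COc1ccc(OC)c(/C=N/NC(=O)Nc2ccc(Oc3ccnc(-c4nncn4CCN(C)C)c3)c(F)c2)c1`, gives 2930 nM in a functional assay on NCI-H460 cells (Homo sapiens) for cytotoxicity, read by MTT assay, with a stated time of 72 h; on this read-out lower numbers stand for stronger inhibition and higher numbers for weaker inhibition.
- Compound 2, `CN(C)CCn1cnnc1-c1cc(Oc2ccc(NC(=O)N/N=C/c3cccc(Cl)c3Cl)cc2F)ccn1`, gives 72 nM in this assay.
- Compound 3, `Cc1cc(/C=N/NC(=O)Nc2ccc(Oc3ccnc(-c4nncn4CCN(C)C)c3)c(F)c2)cc(C)c1O`, gives 2010 nM in this assay.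

Compound 3 stands second highest of the three numbers; its nearest neighbour is compound 1, and the pair differ only within the scatter, while compound 2 lies far below it, as the step of a 28-fold higher number from compound 2 to compound 3 (1.45 log units; beyond the scatter) shows. The three compounds share one core and differ only in the aryl group on a carbon with a double bond to nitrogen. Compound 4, `CN(C)CCn1cnnc1-c1cc(Oc2ccc(NC(=O)N/N=C/c3ccc(O)cc3O)cc2F)ccn1`, carries the change (2,4-dihydroxyphenyl in place of 4-hydroxy-3,5-dimethylphenyl on a carbon with a double bond to nitrogen).

Going by the values given here, two measured steps bear on this. The exchange of one oxygen-bearing aryl for another, a 1.5-fold lower number from compound 1 to compound 3 (0.16 log units; within the scatter), stayed within the scatter, whereas the move to 2,3-dichlorophenyl, a 41-fold lower number from compound 1 to compound 2 (1.61 log units; beyond the scatter), was large. Compound 4 keeps an oxygen-bearing aryl, so the step of a 1.2-fold higher number from compound 3 to compound 4 (0.09 log units; within the scatter) is expected to stay within the scatter, with no clear direction. Compound 4 is therefore estimated at 2500 nM, in a range from 800 nM to 8000 nM.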

Compound 4, half-maximal inhibitory concentration: 11300 nM
The estimate for compound 4 lay 4.5-fold (0.66 log units) below the measured number, outside the stated range (above it).
By their numbers in this assay, from the lowest: compound 2; then compounds 3 and 1 (each within the scatter of the next); then compound 4.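

In this assay oxygen-bearing aryl groups at this position are not interchangeable: 2,4-dihydroxyphenyl gives a 5.6-fold higher number from compound 3 to compound 4 (0.75 log units; beyond the scatter) and a 3.9-fold higher number from compound 1 to compound 4 (0.59 log units; beyond the scatter) with both steps modest but beyond the scatter, whereas the earlier exchange between two such groups stayed within it. Against 2,3-dichlorophenyl the gap widens to a 160-fold higher number from compound 2 to compound 4 (2.20 log units; beyond the scatter) and is large, so this one position spans more than the earlier compounds showed, and the 2,4-dihydroxyphenyl compound is the weakest of the four. Nothing available accounts for the difference between these aryl groups.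

The compounds shown do not tell whether both hydroxyl groups of 2,4-dihydroxyphenyl contribute to this step or only one of them. On these data alone, whether an aryl group carrying a single chlorine, a bromine or an amine would fall nearer compound 2 or compound 4 also stays open.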